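This account rests on a few compounds, and the source may have more. Where it says the series, first, only, none or still open, it means among the compounds named here.

Working notes on the series. Compound 1 `Cc1ccc2c(O)cc(-c3cccc(Cl)c3)nc2n1` in a functional assay on SK-MEL-5 cells (Homo sapiens) for antiproliferative activity (on this read-out lower numbers stand for stronger inhibition of growth and higher numbers for weaker inhibition of growth), gives 31.6 nM; compound 3 `Cc1cc(C)c2c(O)cc(-c3cccc(Cl)c3)nc2n1` gives 117 nM. The step between them, (methyl in place of hydrogen on an aromatic carbon), produced a 3.7-fold higher number from compound 1 to compound 3 (0.57 log units; beyond the scatter). Compound 2 `Oc1cc(-c2ccc3ccccc3c2)nc2ncccc12` gives 3470 nM; how the core of compound 2 differs from that of compound 1 is not broken down here, and the two values alone show compound 2 to be weaker than either compound 1 or compound 3. Compound 4 `Cc1ccc2c(O)cc(-c3ccc4ccccc4c3)nc2n1` is not yet measured in this assay. The change from compound 2 to compound 4 is methyl in place of hydrogen on an aromatic carbon, the same kind of change as from compound 1 to compound 3, though at a place next to the ring nitrogen rather than opposite it, so the earlier step is only a loose guide. For the measured compounds named here, compound 4 is expected to show a 2.3-fold lower number from compound 2 to compound 4 (0.36 log units; beyond the scatter) against compound 2, because the only measured methyl step gave a 3.7-fold higher number from compound 1 to compound 3 (0.57 log units; beyond the scatter) and the different place leaves the direction uncertain. The estimate for compound 4 is 1500 nM, expected to fall between 300 nM and 8000 nM.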

Compound 4, concentration for 50% growth inhibition: 3310 nM
Beside the measured number, compound 4's estimate is 2.2-fold (0.34 log units) below it, within the range that was stated.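

In this assay, methyl in place of hydrogen on an aromatic carbon does not carry over from one core to the other as a fixed shift: the same change on two cores in this assay, a 3.7-fold higher number (0.57 log units; beyond the scatter) from compound 1 to compound 3 and a 1.0-fold lower number (0.02 log units; within the scatter) from compound 2 to compound 4, 3.9-fold (0.59 log units) apart, beyond the scatter of two such steps
The new step, a 1.0-fold lower number from compound 2 to compound 4 (0.02 log units; within the scatter), places compound 2 and compound 4 within the scatter of each other, so methyl next to the ring nitrogen shows no measurable effect on this core. The two steps differ in both the core and the place of the methyl, and these two pairs cannot show which of the two accounts for the gap.

Going by these compounds, whether an ethyl group or an amine at the place of that methyl would follow either step remains open. On these data alone, it also remains open whether a methoxy group there would give a step beyond the scatter.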